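Amide nitrogen substituent variation in a modulator series

The source may hold more compounds than are shown below. What is called first, only, known or untested is meant among the compounds shown, and "the series" means these compounds.

Compound 1 `CC(C)CCNC(=O)c1ccc(C#Cc2ccccc2)nc1` gives 510 nM in a functional assay on BHK cells for positive allosteric modulation of metabotropic glutamate receptor 5 (Homo sapiens), read by FLIPR and calcium flux; a lower number here means that less compound is needed, a higher number that more compound is needed for the effect
Compound 2 `O=C(NC1CCCC1)c1ccc(C#Cc2ccccc2)nc1` gives 30 nM in this assay
Compound 3 `O=C(NCc1ccco1)c1ccc(C#Cc2ccccc2)nc1` gives 180 nM in this assay

Compound 3 stands second highest of the three numbers: a 2.8-fold lower number from compound 1 to compound 3 (0.45 log units; beyond the scatter), while a 6.0-fold higher number from compound 2 to compound 3 (0.78 log units; beyond the scatter). Compound 4 `O=C(c1ccc(C#Cc2ccccc2)nc1)N1CCCCC1` differs from compound 3 by piperidin-1-yl in place of ((furan-2-yl)methyl)amino on a carbonyl carbon. Within the data shown here, the steps that bear on this are a 17-fold lower number from compound 1 to compound 2 (1.23 log units; beyond the scatter) and a 6.0-fold higher number from compound 2 to compound 3 (0.78 log units; beyond the scatter), both favouring a saturated ring directly on the amide nitrogen. Among the measured compounds shown here, no measured step, however, removes the amide hydrogen, so the direction is uncertain. A modest move toward a lower number is expected, a 1.5-fold lower number from compound 3 to compound 4 (0.18 log units; within the scatter). Compound 4 is estimated at 120 nM, within a range of 25 nM to 600 nM.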

Compound 4, half-maximal effective concentration: 280 nM
The estimate for compound 4 lay 2.3-fold (0.37 log units) below the measured number; low and high end bracket the measured number.
By their numbers in this assay, from the lowest: compound 2; then compounds 3, 4 and 1 (each within the scatter of the next, the first and the last beyond it).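

Piperidin-1-yl, which brings no hydrogen-bond donor to the carbonyl carbon, does not keep the low number of cyclopentylamino, with a 9.3-fold higher number from compound 2 to compound 4 (0.97 log units; beyond the scatter). A saturated ring at this position therefore does not by itself give the low number of compound 2. Compound 4 remains within the scatter of the other two amides, with a 1.6-fold higher number from compound 3 to compound 4 (0.19 log units; within the scatter) and a 1.8-fold lower number from compound 1 to compound 4 (0.26 log units; within the scatter). No measurement on these compounds explains the result.

Going by these compounds, whether the gap to compound 2 follows the amide hydrogen or the ring's attachment through nitrogen stays open. An N-methyl-N-cyclopentylamino group on the carbonyl carbon would separate the two.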